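Notes on the thiazolyl exchange at compound 3

The source may report more compounds than this note shows. Statements on the series, on what has been measured and on what is new or still open speak of the compounds shown alone.

Measured so far in a functional assay on HOS-TE85 cells (Homo sapiens) for inhibition, read by CCK-8 assay, with a stated time of 72 h (a lower number here means a stronger inhibitor, a higher number a weaker inhibitor), as follows
- compound 1 `O=C(NCCCCn1cccn1)c1cccc(C2SCC(=O)N2c2ccccn2)c1` gives 60.3 nM 
- compound 2 `Cc1ccnc(N2C(=O)CSC2c2cccc(C(=O)NCCCCn3cccn3)c2)c1` gives 19.6 nM 

Compound 2 stands lowest of the two at 19.6 nM in this pair. Compound 3 `CCOC(=O)c1sc(N2C(=O)CSC2c2cccc(C(=O)NCCCCn3cccn3)c2)nc1C` has not yet been measured. It carries 5-(ethoxycarbonyl)-4-methyl-1,3-thiazol-2-yl in place of 4-methylpyridin-2-yl on an amide-type nitrogen in a ring and otherwise matches compound 2.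

For the measured compounds named here, only one measured step bears on this change, a 3.1-fold lower number from compound 1 to compound 2 (0.49 log units; beyond the scatter) with methyl in place of hydrogen on an aromatic carbon. That step was modest and beyond the scatter, and it was made on the same group that now leaves. Going by the values given here, no measured compound carries the thiazolyl group, so the direction remains uncertain. Among the compounds with values here, the whole group is exchanged, starting from the lowest number so far, so a modest step to a higher number in this assay is the working expectation. The estimated step is a 2.3-fold higher number from compound 2 to compound 3 (0.36 log units; beyond the scatter) with a wide margin on either side. Expected for compound 3 is 45 nM with a range of 10 nM to 200 nM as an estimate.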

Compound 3, half-maximal inhibitory concentration: 430 nM
For compound 3 the middle estimate is 9.6-fold (0.98 log units) below the measured one; the whole stated range lies below it.
By their numbers in this assay, from the lowest: compound 2; then compound 1; then compound 3.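

In this assay, the exchange on the amide-type nitrogen in a ring gives a 22-fold higher number from compound 2 to compound 3 (1.34 log units; beyond the scatter), and the comparison with the unmethylated pyridin-2-yl group gives a 7.1-fold higher number from compound 1 to compound 3 (0.85 log units; beyond the scatter), so the higher number does not depend on which of the two pyridine groups serves as the reference. The earlier pair showed only a modest shift to a lower number from one added methyl, whereas this change shows that the same position can also move the number strongly upward when the whole group is replaced, leaving compound 3 highest of the three. No measurement at hand gives a reason for the size of these steps.

The entering group differs at once in its five-membered aromatic ring with 2 hetero atoms and in its ethoxycarbonyl group, so the compounds shown cannot divide the step between those two features. A 4-methyl-1,3-thiazol-2-yl group without the ester, or a carboxylic acid in place of the ethoxycarbonyl group, would be needed to separate them.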